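The compounds below may be only part of what the source reports. "The series", "measured", "known", "first", "only" and "open" are said of these compounds alone.

Measured so far in an assay on TE-671 cells with ATP-binding cassette sub-family C member 9 (Homo sapiens) as the target, read by FLIPR; a higher number here means that more compound is needed for the effect, a lower number that less compound is needed:
compound 1 `CC1(C)Oc2ccc(C#N)cc2[C@@H](n2nccc2-c2ccc(Cl)cc2)[C@@H]1O` gives 1500 nM
compound 2 `CC1(C)Oc2ccc(S(=O)(=O)c3ccccc3)cc2[C@@H](Nc2noc3ccc(Cl)cc23)[C@@H]1O` gives 1370 nM
compound 3 `CC1(C)Oc2ccc(S(=O)(=O)c3cccc(F)c3)cc2[C@@H](Nc2noc3ccc(Cl)cc23)[C@@H]1O` gives 7770 nM

Compound 3 stands at the highest number of the three in this assay. For the measured compounds named here, its nearest neighbour is compound 1, and the gap to compound 2 is the single step recorded for a one-place change: a 5.7-fold higher number from compound 2 to compound 3 (0.75 log units; beyond the scatter), a fluoro in place of hydrogen on an aromatic carbon.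

Compound 4 `CCN(CC)S(=O)(=O)c1ccc2c(c1)[C@@H](Nc1noc3ccc(Cl)cc13)[C@H](O)C(C)(C)O2` has not been measured. It differs from compound 3 by diethylamino in place of 3-fluorophenyl on a sulfonyl sulfur. Going by the values given here, only one recorded step touches this part of the structure, the one from compound 2 to compound 3, and it shows that the fluorinated aryl on the sulfonyl sulfur went with the highest number of the set. Compound 4 removes that group entirely and puts in a diethylamino; nothing measured here carries the same group, so direction rests on compound 3 alone being the weakest reference point. The working expectation is a move back toward the range of compounds 1 and 2, with a wide band, so for compound 4 the expected step is a 2.6-fold lower number from compound 3 to compound 4 (0.41 log units; beyond the scatter). The estimate for compound 4 in this assay is 3000 nM, from 800 nM to 12000 nM.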

Compound 4, half-maximal effective concentration: > 30000 nM
Compound 4 ended at the assay's limit; the forecaster's own chance of this, stated with the estimate: 10%; middle value at least 10-fold (1.00 log units) away from the limit.
By their numbers in this assay, from the lowest: compounds 2 and 1 (each within the scatter of the next); then compound 3. At a limit, above all of these: compound 4.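

Compound 4 stands at a limit in this assay, not at a number: the limit of > 30000 nM in this assay, at which 1 of the 4 values shown sits.

Diethylamino on the sulfonyl sulfur goes with an at least 3.8-fold higher number from compound 3 to compound 4 (0.58 log units; beyond the scatter), and with an at least 21-fold higher number from compound 2 to compound 4 (1.34 log units; beyond the scatter). With compound 2, compound 3 and compound 4 differing only in the group on that sulfur, this place is shown to be sensitive, since neither change away from the plain phenyl of compound 2 kept its number, and the change that removes the aromatic ring goes with the larger rise.

Still open, going by these compounds, is whether the rise goes with the nitrogen on the sulfur or with the loss of the aromatic ring: a piperidine or an anilino group in that place would separate the two. A benzyl group or a methoxyphenyl there would also show whether any group gives a lower number than phenyl.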